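The compounds below may be only part of what the source reports. "The series", "measured", "known", "first", "only" and "open" are said of these compounds alone.

In an ADME assay on isolated protein for inhibition of Dipeptidyl peptidase 9 (Homo sapiens), with stated times of 15 min, 60 s and 20 min (a lower number here means a stronger inhibitor, a higher number a weaker inhibitor), compound 1 `CC#CCn1c(N2CCC[C@@H](N)C2)nc2c1c(=O)n(Cc1ccccc1C(=O)OC)c(=O)n2C` gives only a limit, > 100000 nM. Compound 2 `CC#CCn1c(N2CCC[C@@H](N)C2)nc2c1c(=O)n(Cc1ccc(Br)cc1C(=O)O)c(=O)n2C` likewise reaches only a limit, > 100000 nM. Both sit at the limit of > 100000 nM in this assay, at which 2 of the 2 values shown sit, so the step that the two limits leave unreadable from compound 1 to compound 2 cannot be read. Compound 3 `CC#CCn1c(N2CCC[C@@H](N)C2)nc2c1c(=O)n(Cc1c(Cl)cccc1C(=O)O)c(=O)n2C` differs from compound 2 by 2-carboxy-6-chlorophenyl in place of 4-bromo-2-carboxyphenyl on a saturated chain carbon bound to an aromatic nitrogen. Among the compounds with values here, no measured step bears on this change, as the single step on hand is unreadable. Compound 3 is therefore expected to remain at the limit, the estimated step of a number no higher from compound 2 to compound 3 (the limit leaves the size open) meaning no readable change. The estimate for compound 3 in this assay is 100000 nM, from 30000 nM to 300000 nM, most likely reported only as a limit.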

Compound 3, half-maximal inhibitory concentration: > 100000 nM
Compound 3 ended at the assay's limit; the forecaster's own chance of this, stated with the estimate: 85%; the middle value lies on the limit itself.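

Compound 1, compound 2 and compound 3 all stand at a limit, so no step among them can be read in this assay: the limit of > 100000 nM in this assay, at which 3 of the 3 values shown sit.

The compounds shown leave open whether 4-bromo-2-carboxyphenyl, 2-carboxy-6-chlorophenyl or 2-(methoxycarbonyl)phenyl differ at all in inhibition.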